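Aryl swap at the two-nitrogen ring: compound 3 to compound 4

The compounds below may be only part of what the source reports. "The series", "measured", "known", "first", "only" and "open" are said of these compounds alone.

For the measured compounds named here, compound 3 `N#Cc1cccc(-c2nc(N)c3cc(Cc4ccccc4)sc3n2)c1` gives 222 nM in a functional assay on CHO-K1 cells for antagonist activity at adenosine receptor A1 (Homo sapiens), read by a beta-galactosidase reporter and cAMP accumulation, with stated times of 15 min and 6 h (a lower number here means a stronger inhibitor, a higher number a weaker inhibitor), the lowest of the three numbers so far. Compound 1 `Cc1ccc(-c2nc(N)c3cc(Cc4ccccc4)sc3n2)o1` gives 298 nM, a gap to compound 3 that lies within the scatter. Compound 2 `Nc1nc(-c2ccc(C3CC3)o2)nc2sc(Cc3ccccc3)cc12` gives 861 nM and sits furthest off. Compound 4 `Nc1nc(-c2cccc(Cl)n2)nc2sc(Cc3ccccc3)cc12` carries 6-chloropyridin-2-yl in place of 3-cyanophenyl on an aromatic carbon. Going by the values given here, no measured step exchanges this same pair of groups; the nearest guides are the aryl swaps at the same place, a 1.3-fold lower number from compound 1 to compound 3 (0.13 log units; within the scatter) and a 3.9-fold lower number from compound 2 to compound 3 (0.59 log units; beyond the scatter), one within the scatter and one modest. A step of about that size, direction open, is expected for compound 4 in this assay. Compound 4 is therefore estimated at 300 nM with a range of 100 nM to 1000 nM. The expected step of a 1.4-fold higher number from compound 3 to compound 4 (0.13 log units; within the scatter) is held to be within the scatter.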

Compound 4, inhibition constant: > 1000 nM
Compound 4 gave a limit, no number (the forecaster's own chance of this, stated with the estimate: 3%); middle value at least 3.3-fold (0.52 log units) away from the limit.
By their numbers in this assay, from the lowest: compounds 3 and 1 (each within the scatter of the next); then compound 2. At a limit, above all of these: compound 4.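

In this assay, the aromatic carbon between two ring nitrogen atoms proves less forgiving than the earlier aryl swaps suggested: 6-chloropyridin-2-yl separates clearly from 3-cyanophenyl (an at least 4.5-fold higher number from compound 3 to compound 4 (0.65 log units; beyond the scatter)) and from 5-methylfuran-2-yl (an at least 3.3-fold higher number from compound 1 to compound 4 (0.52 log units; beyond the scatter)). Against 5-cyclopropylfuran-2-yl the floor stays within the scatter (an at least 1.1-fold higher number from compound 2 to compound 4 (0.06 log units; that floor lies within the scatter)), so no order can be set there. Compound 4 stands at a limit, not a number: the limit of > 1000 nM in this assay, at which 1 of the 4 values shown sits.

On these data alone, how far compound 4 lies beyond that limit remains open. Also open, as far as these compounds go, is whether the step follows the ring nitrogen or the chlorine, which pyridin-2-yl or 3-chlorophenyl at this position could separate.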